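From methyl to trifluoromethoxy on a compound at the limit

A few compounds are considered here, and "the series" means these few. Any claim that something is new, unique, unknown or untested is made for them only; others in the source may bear on it.

In a functional assay on T47D cells (Homo sapiens) for cytotoxicity, read by MTT assay, with a stated time of 2 days (a higher number here means a weaker inhibitor, a lower number a stronger inhibitor), compound 2 `Cc1ccc2nc(-c3ccccc3C)[nH]c(=O)c2c1` reads > 50000 nM as a limit of the assay and not a number. That is all that is known of its standing (the limit of > 50000 nM in this assay, at which 1 of the 3 values shown sits). Real numbers come from two related compounds, where compound 1 `Cc1ccc2nc(-c3ccccc3N(C)C)[nH]c(=O)c2c1` gives 26700 nM and compound 3 `Cc1ccc2c(=O)[nH]c(-c3ccccc3N(C)C)nc2c1` gives 4430 nM under the same conditions.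

Compound 4 `Cc1ccc2nc(-c3ccccc3OC(F)(F)F)[nH]c(=O)c2c1` carries trifluoromethoxy in place of methyl on an aromatic carbon. Among the compounds with values here, only one measured step touches that place (an at least 1.8-fold higher number from compound 1 to compound 2 (0.27 log units; that floor lies within the scatter)) and it put methyl in place of dimethylamino. That step is only a floor and it lies within the scatter, so it fixes no firm size. A small step is therefore expected in this assay toward a lower number, meaning a somewhat stronger inhibitor, or none beyond the scatter. Compound 4 is estimated at 35000 nM (expected range 12000 nM to 70000 nM). The expected move is an at least 1.4-fold lower number from compound 2 to compound 4 (0.15 log units; that floor lies within the scatter) on this estimate.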

Compound 4, half-maximal inhibitory concentration: > 50000 nM
Compound 4: no number, only a limit; the forecaster's own chance of this, stated with the estimate: 45%; middle value at least 1.4-fold (0.15 log units) from the limit.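

In this assay, compound 4 sits at the assay's limit alongside compound 2, so trifluoromethoxy, like methyl, yields a limit rather than a number on this aromatic carbon: the limit of > 50000 nM in this assay, at which 2 of the 4 values shown sit.

With two limits, the step between compound 2 and compound 4 cannot be read. Among these three compounds, only the one with dimethylamino gives a real number, and putting trifluoromethoxy in its place gives an at least 1.8-fold higher number from compound 1 to compound 4 (0.27 log units; that floor lies within the scatter); this is only a floor, so it fixes no firm size.

On these data alone, it remains open whether a primary amine, a methylamino group or a methoxy group at this place would give a real number. As far as these compounds go, it is also open whether trifluoromethoxy on the core of compound 3 would do so.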